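A few compounds are considered here, and "the series" means these few. Any claim that something is new, unique, unknown or untested is made for them only; others in the source may bear on it.

In an ADME assay (liver) for metabolic stability, with Liver microsome (Rattus norvegicus) as the target, using microsomes and NADPH, with a stated time of 30 min, tested at 1 uM (on this read-out higher numbers stand for fast clearance and lower numbers for slow clearance), compound 1 (`Nc1ccc(S(=O)(=O)N2CCN(c3ncc(C(O)(C(F)(F)F)C(F)(F)F)cc3Br)CC2)cn1`) gives 32 mL.min-1.g-1, compound 2 (`CC(C)(O)C#Cc1cc(C(O)(C(F)(F)F)C(F)(F)F)cnc1N1CCN(S(=O)(=O)c2ccc(N)nc2)CC1`) gives 16 mL.min-1.g-1 and compound 3 (`Cn1cc(-c2cc(C(O)(C(F)(F)F)C(F)(F)F)cnc2N2CCN(S(=O)(=O)c3ccc(N)nc3)CC2)cn1`) gives 44 mL.min-1.g-1. The steps into the last of these are a 1.4-fold higher number from compound 1 to compound 3 (0.14 log units; within the scatter) and a 2.8-fold higher number from compound 2 to compound 3 (0.44 log units; beyond the scatter), so compound 3 sits level with compound 1 and above compound 2. Compound 4 (`CC(C)n1cc(-c2cc(C(O)(C(F)(F)F)C(F)(F)F)cnc2N2CCN(S(=O)(=O)c3ccc(N)nc3)CC2)cn1`) carries isopropyl in place of methyl on an aromatic nitrogen. Among the measured compounds shown here, no measured step alters that nitrogen substituent. The measured steps replace the whole group on an aromatic carbon, and the largest of them is a 2.8-fold higher number from compound 2 to compound 3 (0.44 log units; beyond the scatter). A smaller change is therefore expected here, with nothing beyond the scatter and a slight rise at most. The expected change is a 1.3-fold higher number from compound 3 to compound 4 (0.10 log units; within the scatter). Compound 4 is expected at 55 mL.min-1.g-1, with an estimated range of 30 mL.min-1.g-1 to 100 mL.min-1.g-1.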

Compound 4, intrinsic clearance in microsomes: 198 mL.min-1.g-1
For compound 4 the middle estimate is 3.6-fold (0.56 log units) below the measured one; measured number above the stated range.
By their numbers in this assay, from the lowest: compounds 2, 1 and 3 (each within the scatter of the next, the first and the last beyond it); then compound 4.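

In this assay, the aromatic nitrogen of the five-membered ring is a sensitive place: isopropyl in place of methyl alone gives a 4.5-fold higher number from compound 3 to compound 4 (0.65 log units; beyond the scatter). The earlier compounds shown here showed only changes of the whole group on the aromatic carbon, and bromo and 1-methyl-1H-pyrazol-4-yl lay within the scatter of each other, whereas 1-isopropyl-1H-pyrazol-4-yl gives a 6.2-fold higher number from compound 1 to compound 4 (0.79 log units; beyond the scatter) and a 12-fold higher number from compound 2 to compound 4 (1.09 log units; beyond the scatter). Nothing available accounts for this rise. Going by these compounds, whether ethyl or cyclopropyl on that nitrogen stays near compound 3 or approaches compound 4 remains open.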